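Adding a Methyl to the Piperidine of Compound 2

This account rests on a few compounds, and the source may have more. Where it says the series, first, only, none or still open, it means among the compounds named here.

Compound 1 `COc1cc2c(Oc3ccc(NC(=O)/C=C/S(=O)(=O)c4ccccc4OC)cc3F)ccnc2cc1OCCCN1CCN(C)CC1`: in a functional assay on MKN-45 cells (Homo sapiens) for cytotoxicity, read by MTT assay, with a stated time of 72 h (on this read-out higher numbers stand for weaker inhibition and lower numbers for stronger inhibition), compound 1 gives 430 nM.
Compound 2 `COc1cc2c(Oc3ccc(NC(=O)/C=C/S(=O)(=O)c4ccccc4OC)cc3F)ccnc2cc1OCCCN1CCCCC1`: in this assay compound 2 gives 980 nM.
Compound 3 `COc1ccc(S(=O)(=O)/C=C/C(=O)Nc2ccc(Oc3ccnc4cc(OCCCN5CCCCC5)c(OC)cc34)c(F)c2)cc1`: in this assay compound 3 gives 3580 nM.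

Compound 2 sits second highest of the three numbers. Its nearest neighbour is compound 1, which differs only in the basic ring at the end of the three-carbon chain; that change reads a 2.3-fold higher number from compound 1 to compound 2 (0.36 log units; beyond the scatter). The step at the other end of the molecule, where the methoxyphenyl on the sulfonyl sulfur is swapped, reads a 3.7-fold higher number from compound 2 to compound 3 (0.56 log units; beyond the scatter).

Compound 4 `COc1cc2c(Oc3ccc(NC(=O)/C=C/S(=O)(=O)c4ccccc4OC)cc3F)ccnc2cc1OCCCN1CCC(C)CC1` keeps everything in compound 2 and differs by one change: methyl in place of hydrogen on a saturated ring carbon of the piperidine.

Within the data shown here, no measured step changes this ring position, so nothing bears directly on the change. The closest comparison, compound 1 to compound 2, replaces the whole ring rather than adding a methyl to it, and even that step was modest. A single added methyl far out on the chain is therefore expected to give at most a small step in this assay, likely within the scatter, with no clear direction.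

Compound 4 is accordingly estimated at 950 nM, within 400 nM to 2300 nM, meaning an expected step of a 1.0-fold lower number from compound 2 to compound 4 (0.01 log units; within the scatter).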

Compound 4, half-maximal inhibitory concentration: 2030 nM
Compound 4: the middle estimate sits 2.1-fold (0.33 log units) below what was measured, within the range that was stated.
By their numbers in this assay, from the lowest: compound 1; then compound 2; then compounds 4 and 3 (each within the scatter of the next).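

In this assay, a single methyl on this saturated ring carbon, three ring bonds from the ring nitrogen, is enough to move the number: the change reads a 2.1-fold higher number from compound 2 to compound 4 (0.32 log units; beyond the scatter). This shows that the far end of the chain responds to a small addition to the ring and not only to replacing the whole ring. The comparison between the methyl-bearing rings, 4-methylpiperidin-1-yl in place of 4-methylpiperazin-1-yl, reads a 4.7-fold higher number from compound 1 to compound 4 (0.67 log units; beyond the scatter), and no measurement offers a reason for either step.

The compounds shown leave open whether the step depends on where the methyl sits or on its size, which a 3-methylpiperidin-1-yl or a 4-ethylpiperidin-1-yl ring would test, and whether an oxygen-bearing group such as the hydroxyl of a 4-hydroxypiperidin-1-yl ring would read differently from the methyl. They also leave open whether adding the methyl gives a similar step when the sulfonyl sulfur carries 4-methoxyphenyl in place of 2-methoxyphenyl.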